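The source may report more compounds than this note shows. Statements on the series, on what has been measured and on what is new or still open speak of the compounds shown alone.

Measured so far in a functional assay on SW 1116 cells (Homo sapiens) for antiproliferative activity, read by MTT assay, with a stated time of 24 h; a higher number here means a weaker inhibitor, a lower number a stronger inhibitor
compound 1 `O=[N+]([O-])c1cccc(CSc2nnc(-c3ccc4c(c3)OCCO4)n2-c2ccccc2)c1` gives 7590 nM
compound 2 `Fc1ccc(CSc2nnc(-c3ccc4c(c3)OCCO4)n2-c2ccccc2)cc1` gives 20800 nM

Compound 2 at 20800 nM holds the higher of the two numbers and is the weaker inhibitor of the pair. Compound 3 `Brc1ccc(CSc2nnc(-c3ccc4c(c3)OCCO4)n2-c2ccccc2)cc1` differs from compound 2 in one place, bromo in place of fluoro on an aromatic carbon with bromo in place of fluoro on an aromatic carbon, para to a large group. Within the data shown here, only one measured step bears on this ring, a 2.7-fold higher number from compound 1 to compound 2 (0.44 log units; beyond the scatter) and it was modest and exchanged other groups, 4-fluorophenyl in place of 3-nitrophenyl. Among the measured compounds shown here, no bromo compound has been measured, so the direction remains uncertain. A smaller step is expected, leaning slightly towards a lower number in this assay since compound 2 at 20800 nM sits at the top of the pair. The expected change is a 1.5-fold lower number from compound 2 to compound 3 (0.17 log units; within the scatter) and it may not exceed the scatter. For compound 3 the estimated value is 14000 nM with an expected range from 6000 nM to 32000 nM overall.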

Compound 3, half-maximal inhibitory concentration: 5810 nM
Compound 3: the middle estimate sits 2.4-fold (0.38 log units) above what was measured, and the stated range ends above it.
By their numbers in this assay, from the lowest: compounds 3 and 1 (each within the scatter of the next); then compound 2.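

In this assay the halogen alone proved enough to move the number, with a 3.6-fold lower number from compound 2 to compound 3 (0.55 log units; beyond the scatter) while the benzyl link, the sulfur and the shared core stayed the same, so this aromatic carbon responds to the exchange of fluoro for bromo. The comparison with the 3-nitrophenyl compound adds a second point, as a 1.3-fold lower number from compound 1 to compound 3 (0.12 log units; within the scatter) places the 4-bromobenzyl and 3-nitrobenzyl compounds within the scatter of each other, and the gap first seen between compound 1 and compound 2 therefore does not hold for every halogen on this ring. No measurement on hand accounts for the difference between bromo and fluoro here.

The compounds shown leave open whether chloro, methyl or methoxy on this same carbon would fall with compound 3 or with compound 2. They also leave open whether an amine or a carboxylic acid would be tolerated there.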